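The source may report more compounds than this note shows. Statements on the series, on what has been measured and on what is new or still open speak of the compounds shown alone.

In a functional assay on cells (Panel leukemia (Carcinoma cell lines), Homo sapiens) for inhibition, read by sulforhodamine B assay, with a stated time of 48 h; a higher number here means a weaker inhibitor of growth, a lower number a stronger inhibitor of growth:
- compound 1 `CN1CCN(CCCOc2cccc3nc(Nc4ccc(Cl)c(C(F)(F)F)c4)ccc23)CC1`: 3480 nM
- compound 2 `CN1CCN(CCCOc2cccc3nc(Nc4ccc(Cl)c(F)c4)ccc23)CC1`: 4280 nM

Among the measured compounds shown here, only two numbers exist so far, and compound 1 stands level with the other one: a 1.2-fold higher number from compound 1 to compound 2 (0.09 log units; within the scatter).

Compound 3 `CN1CCN(CCCOc2cccc3nc(Nc4cccc(Cl)c4)ccc23)CC1` has not yet been measured. Its difference from compound 1 is 3-chlorophenyl in place of 4-chloro-3-(trifluoromethyl)phenyl on a nitrogen on an aromatic ring.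

For the measured compounds named here, only one measured step bears on this, and only in part: a 1.2-fold higher number from compound 1 to compound 2 (0.09 log units; within the scatter). That step also replaces the trifluoromethyl group, and it stays within the scatter. Going by the values given here, no measured compound carries the 3-chlorophenyl group, so the support is thin. No step beyond the scatter is expected in this assay, and no firm direction can be drawn. The expected step is a 1.2-fold higher number from compound 1 to compound 3 (0.08 log units; within the scatter). For compound 3 the estimate is 4200 nM, with an expected range of 2400 nM to 7500 nM.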

Compound 3, concentration for total growth inhibition: 4650 nM
Beside the measured number, compound 3's estimate is 1.1-fold (0.04 log units) below it; low and high end bracket the measured number.
By their numbers in this assay, from the lowest: compounds 1, 2 and 3 (each within the scatter of the next).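

In this assay, the 3-chlorophenyl group on a nitrogen on an aromatic ring reads level with the 4-chloro-3-(trifluoromethyl)phenyl group: a 1.3-fold higher number from compound 1 to compound 3 (0.13 log units; within the scatter). It also reads level with the 4-chloro-3-fluorophenyl group: a 1.1-fold higher number from compound 2 to compound 3 (0.04 log units; within the scatter). This position therefore accepts all three groups with no step beyond the scatter, and no supporting data explain this.

Still open, as far as these compounds go, is whether an amine, a carboxylic acid or a plain phenyl group at this position would also stay within the scatter of these three compounds. Also open, from the compounds shown here alone, is whether a longer chain between the shared core and its terminal amine would shift the number, since all three compounds carry the same chain.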